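The compounds below may be only part of what the source reports. "The series", "measured", "known", "first", "only" and "open" are said of these compounds alone.

Compounds that open the cold-sensing ion channel can be compared by the amount of compound needed to produce a response. In an assay on HEK293 cells for agonist activity at transient receptor potential cation channel subfamily M member 8 (Homo sapiens), read by fluorescence and calcium flux, with a stated time of 15 min (on this read-out higher numbers stand for an effect only at larger amounts of compound and lower numbers for an effect already at smaller amounts), compound 1, `COc1ccc2oc(C(=O)N(Cc3cccs3)c3ccn[nH]3)cc2c1`, gives 1.1 nM. Compound 2, `Cc1ccc(OCC(=O)N(Cc2cccs2)C2CC2)cc1`, gives 8 nM in this assay. Of the two numbers at hand, the number of compound 2 is the higher one, and the gap to compound 1 lies beyond the usual scatter of this assay, so compound 1 acts at smaller amounts than compound 2 does. A third compound, compound 3, `CCN(Cc1cc[nH]n1)C(=O)COc1ccc(C)cc1`, is reported in this assay as "not active" (no number reported), without a number.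

The next compound, compound 4, `Cc1ccc(OCC(=O)N(O)Cc2cccs2)cc1`, has not yet been measured. It differs from compound 2 in one place: hydroxy in place of cyclopropyl on an amide-type nitrogen. Going by the values given here, no measured pair shows this particular change, so its effect in this assay can only be guessed. The loss of a ring of carbon and the arrival of a group that both gives and takes a hydrogen bond is a sizeable change, and compound 3 shows that changes at this part of the molecule can remove activity entirely. Compound 4 is therefore expected to need larger amounts than compound 2, with a step from compound 2 to compound 4 estimated at a 13-fold higher number from compound 2 to compound 4 (1.10 log units; beyond the scatter). The estimate for compound 4 in this assay is 100 nM, with a range from 15 nM to 1500 nM.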

Compound 4, half-maximal effective concentration: 8000 nM
Estimate against measurement, compound 4: 80-fold (1.90 log units) below, and the stated range ends below it.
By their numbers in this assay, from the lowest: compound 1; then compound 2; then compound 4.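

In this assay the exchange of cyclopropyl for hydroxy on the amide-type nitrogen gives a 1000-fold higher number from compound 2 to compound 4 (3.00 log units; beyond the scatter) and is the only difference between the two structures, so this single group has a very large effect on the amount of compound needed. Compound 4 still has a measured number, however, so this change raises the amount needed without removing the response altogether. The exchange takes away a three-membered ring of three carbons and brings in one oxygen with a hydrogen-bond donor and acceptor, but no measurement here explains why the step is so large.

The two compounds cannot separate the loss of the cyclopropyl ring from the arrival of the hydroxy, since both happen in the same step. An isopropyl group or a cyclobutyl ring on this nitrogen would test the effect of keeping carbon there, while a methoxy group would keep the oxygen but replace the hydroxy hydrogen with a methyl group, and the compounds shown leave open where any of these would fall.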